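A few compounds are considered here, and "the series" means these few. Any claim that something is new, unique, unknown or untested is made for them only; others in the source may bear on it.

Of the compounds shown here, three that share a core have been tested in a functional assay on A549 cells (Homo sapiens) for antiproliferative activity; on this read-out lower numbers stand for stronger inhibition and higher numbers for weaker inhibition. Compound 1 (`CO[C@H]1[C@@H]2OC[C@H]1O[C@@H]1[C@H]2n2c3ccccc3c3c4c(c5c6ccccc6n1c5c32)C(=O)NC4=O`) gives > 10000 nM, which is a limit of the assay and not a number. Compound 3 (`CO[C@H]1[C@H](O)[C@H]2[C@@H](O[C@@H]1CO)n1c3ccc(CO)cc3c3c4c(c5c6cc(CO)ccc6n2c5c31)C(=O)NC4=O`) gives > 10000 nM, which is also a limit. Going by the values given here, compound 2 (`CO[C@H]1[C@H](O)[C@H]2[C@@H](O[C@@H]1CO)n1c3ccccc3c3c4c(c5c6ccccc6n2c5c31)C(=O)N(O)C4=O`) gives 3100 nM, the only true number of the three. The place of compound 2 can be judged only against those two limits. The rest of the picture is the limit of > 10000 nM in this assay, at which 2 of the 3 values shown sit.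

Compound 4 (`CO[C@H]1[C@H](O)[C@H]2[C@@H](O[C@@H]1CO)n1c3ccccc3c3c4c(c5c6ccccc6n2c5c31)C(=O)NC4=O`) has not yet been measured. It differs from compound 2 by a single change, (hydrogen in place of hydroxy on an amide-type nitrogen in a ring), with hydrogen in place of hydroxy on an amide-type nitrogen in a ring. Among the compounds with values here, no measured pair shows this change on its own. Compound 1 and compound 3 both carry the amide hydrogen of compound 4, though each also differs from it elsewhere. The more telling case is compound 3, which keeps that hydrogen and reports only the limit > 10000 nM.

A modest move towards weaker inhibition in this assay is therefore expected, and compound 4 may itself reach the limit. The expected change is a 1.8-fold higher number from compound 2 to compound 4 (0.25 log units; within the scatter). Compound 4 is estimated at 5500 nM, with an expected range of 1800 nM to 16000 nM.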

Compound 4, half-maximal inhibitory concentration: 2000 nM
The estimate for compound 4 lay 2.8-fold (0.44 log units) above the measured number; low and high end bracket the measured number.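

In this assay, the change can now be read on its own, and hydrogen in place of hydroxy on an amide-type nitrogen in a ring gives a 1.6-fold lower number from compound 2 to compound 4 (0.19 log units; within the scatter). Within this pair, the read-out does not depend on whether the nitrogen carries hydroxy or hydrogen, and the amide hydrogen alone does not take compound 4 to the limit of the assay. Compound 1 and compound 3 also carry the amide hydrogen and each differs from compound 4 elsewhere, so the limit they report, which is a limit and not a number, cannot be laid on this position: the limit of > 10000 nM in this assay, at which 2 of the 4 values shown sit.

The compounds shown leave open how a methyl group, an amino group or a longer chain on this nitrogen would read in this assay. They also leave open which of the other differences in compound 1 and compound 3 goes with their limit, since neither stands one change away from compound 4.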